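A few compounds are considered here, and "the series" means these few. Any claim that something is new, unique, unknown or untested is made for them only; others in the source may bear on it.

Measured in an assay on lysate for inhibition of phosphatidylcholine:ceramide cholinephosphotransferase 2 (Homo sapiens), read by HPLC, with stated times of 30 min and 2 h; a higher number here means a weaker inhibitor, a lower number a stronger inhibitor:
compound 1 `O=C(Nc1cccnc1)c1ccccc1OCc1ccccc1F` gives 3500 nM
compound 2 `O=C(Nc1cccnc1)c1ccccc1OCc1ccccc1Cl` gives 1100 nM
compound 3 `O=C(Nc1cccnc1)c1ccccc1OCc1cccc(F)c1` gives 1600 nM

Compound 4 `O=C(Nc1cccnc1)c1ccccc1OCc1cccc(Cl)c1` has not yet been measured in this assay.

Between compound 1 and compound 2 the change is chloro in place of fluoro on an aromatic carbon; it made a 3.2-fold lower number from compound 1 to compound 2 (0.50 log units; beyond the scatter). Compound 3 differs from compound 1 by 3-fluorophenyl in place of 2-fluorophenyl on a saturated chain carbon bound to an oxygen on an aromatic ring; the two cores hold the same atoms joined differently, and the step was a 2.2-fold lower number from compound 1 to compound 3 (0.34 log units; beyond the scatter). Compound 2 and compound 3 lie a 1.5-fold higher number from compound 2 to compound 3 (0.16 log units; within the scatter) apart.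

Compound 4 differs from compound 3 by chloro in place of fluoro on an aromatic carbon. This is the same kind of change as that between compound 1 and compound 2, not the same one: there the site was ortho to a large group, here it is meta to a large group. Among the compounds with values here, only that one earlier step is available, so the expectation rests on it alone, with some allowance for the different surroundings. The step from compound 3 to compound 4 in this assay is expected to be a 2.7-fold lower number from compound 3 to compound 4 (0.43 log units; beyond the scatter). For compound 4 the estimate in this assay is 600 nM, expected to fall between 300 nM and 1300 nM.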

Compound 4, half-maximal inhibitory concentration: 1400 nM
For compound 4 the middle estimate is 2.3-fold (0.37 log units) below the measured one; measured number above the stated range.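

In this assay, chloro in place of fluoro does not carry over from one core to the other with the same size: the same change on two cores in this assay, a 3.2-fold lower number (0.50 log units; beyond the scatter) from compound 1 to compound 2 and a 1.1-fold lower number (0.06 log units; within the scatter) from compound 3 to compound 4, 2.8-fold (0.44 log units) apart, beyond the scatter of two such steps On the core of compound 3 the change gives a 1.1-fold lower number from compound 3 to compound 4 (0.06 log units; within the scatter), so it has no readable effect there, and the two chloro compounds also lie within the scatter of each other, at a 1.3-fold higher number from compound 2 to compound 4 (0.10 log units; within the scatter). Within the data shown here, compound 1 remains the weakest of the four, with a 2.5-fold lower number from compound 1 to compound 4 (0.40 log units; beyond the scatter), so the difference between the two cores rests on the single value of compound 1; with only one pair on each core, this shows no reason for the difference and gives no guide to a further core.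

Still open, as far as these compounds go, is whether bromo, methyl or trifluoromethyl in place of the halogen would follow chloro or fluoro on either core. Also open, from the compounds shown here alone, is how an amine or a carboxylic acid on the shared core would read in this assay.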